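Isopropyl to tert-butyl on two cores: microsomal stability notes

The source may report more compounds than this note shows. Statements on the series, on what has been measured and on what is new or still open speak of the compounds shown alone.

Compound 1 `CC(C)n1ccnc1/N=C(\N)Nc1ccc(Cl)c(Cl)c1` and compound 2 `CC(C)(C)n1ccnc1/N=C(\N)Nc1ccc(Cl)c(Cl)c1` share one core; compound 3 `CC(C)n1ccnc1/N=C(/NC(=O)C(C)(C)C)Nc1ccc(Cl)c(Cl)c1` and compound 4 `CC(C)(C)C(=O)N/C(=N/c1nccn1C(C)(C)C)Nc1ccc(Cl)c(Cl)c1` share another, and the difference between the two cores is not broken down here. In an in vitro ADME assay on microsomes from liver (Homo sapiens) for metabolic stability, read by LC-MS, tested at 1 uM (on this read-out higher numbers stand for a longer-lived compound and lower numbers for a shorter-lived compound), compound 1 gives > 1 h, which is a limit of the assay. In this assay compound 2 also gives > 1 h, again a limit. The change between them is methyl in place of hydrogen on a saturated chain carbon bound to an aromatic nitrogen and two saturated chain carbons, and the step is a step that the two limits leave unreadable from compound 1 to compound 2. In this assay compound 3 gives > 1 h, once more a limit. Compound 4 carries the same change on the other core, (methyl in place of hydrogen on a saturated chain carbon bound to an aromatic nitrogen and two saturated chain carbons), at a place described in the same words. Because of the limit of > 1 h in this assay, at which 3 of the 3 values shown sit, compound 4 is expected to stay at the limit, with an expected step that the limit leaves unreadable from compound 3 to compound 4 and an estimated value of 2 h in this assay.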

Compound 4, half-life: > 1 h
Compound 4: no number, only a limit (the forecaster's own chance of this, stated with the estimate: 85%); the middle value lies beyond the limit too.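

No step can be read from compound 3 to compound 4 in this assay because the result is again a limit: the limit of > 1 h in this assay, at which 4 of the 4 values shown sit.

The compounds shown leave open whether isopropyl to tert-butyl changes half-life on either core.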